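Swapping Methoxy for Chloro on a Shared Urea Core

A few compounds are considered here, and "the series" means these few. Any claim that something is new, unique, unknown or untested is made for them only; others in the source may bear on it.

Of the compounds shown here, three have been measured in a physicochemical assay for lipophilicity; on this read-out lower numbers stand for lower lipophilicity and higher numbers for higher lipophilicity. In this assay compound 1 `CN1CCN(CCCS(=O)(=O)c2ccc3nc(NC(=O)NC(=O)c4cc(N5CCCC5)c(C#N)cc4Cl)sc3c2)CC1` gives 2.8, and compound 2 `CS(=O)(=O)c1ccc2sc(NC(=O)NC(=O)c3ccccc3Cl)nc2c1` gives 2.8. Compound 3 `COc1cc(Cl)c(C(=O)NC(=O)Nc2nc3ccc(S(=O)(=O)CCCN4CCN(C)CC4)cc3s2)cc1-n1cccn1` gives 2.2, the lowest of the three numbers; its nearest neighbour, compound 1, stands higher by a margin beyond the usual scatter, and compound 2 stands equally far above it.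

Compound 4 `CN1CCN(CCCS(=O)(=O)c2ccc3nc(NC(=O)NC(=O)c4cc(-n5cccn5)c(Cl)cc4Cl)sc3c2)CC1` differs from compound 3 in a single place: chloro in place of methoxy on an aromatic carbon. Among the measured compounds shown here, no measured pair shows this exact change, so its size cannot be read off from the data and must be expected. The step of a number 0.70 log units higher from compound 3 to compound 4 (beyond the scatter) is expected to be upward and beyond the scatter. Compound 4 is therefore estimated at 2.9, within a range from 2.4 to 3.4.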

Compound 4, distribution coefficient: 2.3
Beside the measured number, compound 4's estimate is 0.60 log units above it; the whole stated range lies above it.
By their numbers in this assay, from the lowest: compounds 3 and 4 (each within the scatter of the next); then compounds 1 and 2 (each within the scatter of the next).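

Among the compounds shown here, this pair is the first among the measured compounds to differ in one place, so it gives a direct reading of this position, ortho to a 1H-pyrazol-1-yl group and para to a large group. In this assay, chloro in place of methoxy gives a number 0.10 log units higher from compound 3 to compound 4 (within the scatter), so this pair does not separate the two groups on this read-out. No measured evidence explains this result.

From the compounds shown here alone, whether an amine or a carboxylic acid at this position would give a step beyond the scatter remains open. So does whether the same swap would give a similar step at another position.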